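The source may report more compounds than this note shows. Statements on the series, on what has been measured and on what is new or still open speak of the compounds shown alone.

Compound 2 `FC(F)(F)c1ccccc1NC(=S)N/N=C/c1ccc2ccccc2n1` carries a trifluoromethyl-bearing aryl ring on its thiosemicarbazone, and in a functional assay on HeLa cells (Homo sapiens) for antiproliferative activity, read by sulforhodamine B assay, with a stated time of 72 h (on this read-out higher numbers stand for weaker inhibition and lower numbers for stronger inhibition), compound 2 gives 18800 nM. Among the three compounds measured, compound 2 has the highest number: compound 3 `NC(=S)N/N=C/c1cc2cccnc2s1` gives 6290 nM in this assay, a gap beyond the scatter, and compound 1 `CN(C)C(=S)N/N=C/c1ccc2ccccc2n1`, with a dimethylamino group in place of the aryl amine, gives 90 nM, the widest gap. Compound 4 `Cc1ccccc1NC(=S)N/N=C/c1ccc2ccccc2n1` differs from compound 2 by methyl in place of trifluoromethyl on an aromatic carbon. Among the compounds with values here, no measured pair shows this exact change, so the expected step from compound 2 to compound 4 is a 1.9-fold lower number from compound 2 to compound 4 (0.27 log units; within the scatter), toward a somewhat lower number but close to the scatter. In this assay compound 4 is therefore estimated at 10000 nM, within a range of 2500 nM to 40000 nM.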

Compound 4, half-maximal inhibitory concentration: > 100000 nM
Compound 4 gave a limit, no number; the forecaster's own chance of this, stated with the estimate: 5%; at least 10-fold (1.00 log units) between middle value and limit.
By their numbers in this assay, from the lowest: compound 1; then compound 3; then compound 2. At a limit, above all of these: compound 4.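

Methyl in place of trifluoromethyl on an aromatic carbon, ortho to a large group, gives an at least 5.3-fold higher number from compound 2 to compound 4 (0.72 log units; beyond the scatter), so activity at this position depends on which of these two groups it carries, which no earlier pair could show. For compound 4 the value > 100000 nM is a limit, not a number. The step therefore gives only a minimum size: the limit of > 100000 nM in this assay, at which 1 of the 4 values shown sits.

Going by these compounds, how an amine or a methoxy group would behave on this same carbon remains open. So does the effect of a bare hydrogen there.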